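Propanoylamino to acetamido: working notes on the series

The source may hold more compounds than are shown below. What is called first, only, known or untested is meant among the compounds shown, and "the series" means these compounds.

compound 1 `CCC(=O)Nc1cccc(C(=O)/C=C2/C(=O)Nc3ccccc32)c1` gives 11500 nM
compound 2 `O=C1Nc2ccccc2/C1=C\C(=O)c1ccccc1F` gives 17400 nM

In a functional assay on SGC-7901 cells (Homo sapiens) for inhibition, read by MTT assay, with a stated time of 72 h (a higher number here means a weaker inhibitor, a lower number a stronger inhibitor), compound 1 at 11500 nM and compound 2 at 17400 nM lie within the usual scatter of each other, so the two cannot be ranked. Going by the values given here, compound 1 therefore stands level with the only other measured compound, and the data hold no step between measured compounds that differ in one place.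

The next compound is compound 3 `CC(=O)Nc1cccc(C(=O)/C=C2/C(=O)Nc3ccccc32)c1`, which has hydrogen in place of methyl on a saturated chain carbon bound to a carbonyl carbon, so that propanoylamino becomes acetamido (hydrogen in place of methyl on a saturated chain carbon bound to a carbonyl carbon). Among the compounds with values here, with no measured step to go by, no change beyond the scatter is expected in this assay, and the expectation starts from compound 1 at 11500 nM as the closest measured structure. The estimated shift is a 1.0-fold higher number from compound 1 to compound 3 (0.02 log units; within the scatter) and stays within the scatter. The estimate for compound 3 is 12000 nM with an expected range from 5000 nM to 28000 nM as the working figure.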

Compound 3, half-maximal inhibitory concentration: 14100 nM
Beside the measured number, compound 3's estimate is 1.2-fold (0.07 log units) below it; the range from low to high includes it.
By their numbers in this assay, from the lowest: compounds 1, 3 and 2 (each within the scatter of the next).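

Going by these compounds alone, this is the first step that can be read at a single place: on a saturated chain carbon bound to a carbonyl carbon, hydrogen in place of methyl gives a 1.2-fold higher number from compound 1 to compound 3 (0.09 log units; within the scatter) in this assay. At this position, propanoylamino and acetamido therefore cannot be told apart in this assay, so shortening ethyl to methyl on this acyl chain leaves no readable mark on the number for this one pair. Nothing at hand bears on what lies behind this result.

From the compounds shown here alone, the step covers only the short end of the acyl chain, so it remains open whether a longer chain such as butanoyl or hexanoyl, or a branched one such as pivaloyl, would move the number beyond the scatter. Also open, going by these compounds, is whether a terminal amine or carboxylic acid on that chain, or a cyclopropyl ring in place of the ethyl, would leave the number as flat as this exchange does.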